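Chloro in Place of Dimethylamino: Expected Cytotoxicity

A few compounds are considered here, and "the series" means these few. Any claim that something is new, unique, unknown or untested is made for them only; others in the source may bear on it.

Compound 1 `Cc1ccc2nc(Cl)c(/C=C3\C(=O)N(c4c(Cl)cccc4Cl)c4ccccc43)cc2c1C`: "not determined" (no result reported)
Compound 2 `CN(C)c1ccc(/C=C2\C(=O)N(c3c(Cl)cccc3Cl)c3ccccc32)cc1`: > 100 ug/mL

In a functional assay on MIA PaCa-2 cells (Homo sapiens) for cytotoxicity, read by MTT assay, with a stated time of 72 h (on this read-out higher numbers stand for an effect only at larger amounts of compound and lower numbers for an effect already at smaller amounts), compound 2 gives only a limit of the assay, > 100 ug/mL. Compound 1 has no result in this assay, recorded as "not determined" (no result reported). Among the compounds with values here, of the two entries, one sits at the limit (the limit of > 100 ug/mL in this assay, at which 1 of the 2 values shown sits), so there is no measured step from which to read how a change on the aromatic ring shifts the read-out.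

Compound 3 `O=C1/C(=C\c2ccc(Cl)cc2)c2ccccc2N1c1c(Cl)cccc1Cl` differs from compound 2 in one place: chloro in place of dimethylamino on an aromatic carbon. Since compound 2 sits at the limit (the limit of > 100 ug/mL in this assay, at which 1 of the 2 values shown sits), the step to compound 3 cannot be read from existing numbers; a move in either direction beyond the usual scatter is possible. Compound 3 is expected to give 60 ug/mL, with a likely range from 15 ug/mL to 200 ug/mL. The expected step of an at least 1.6-fold lower number from compound 2 to compound 3 (0.22 log units; that floor lies within the scatter) is thus a guess toward a slightly smaller concentration, held loosely.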

Compound 3, concentration for half-maximal effect: 5 ug/mL
The estimate for compound 3 lay 12-fold (1.08 log units) above the measured number; the whole stated range lies above it.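

In this assay, putting chloro in place of dimethylamino on this aromatic carbon, para to a large group, gives an at least 20-fold lower number from compound 2 to compound 3 (1.30 log units; beyond the scatter). This single change is therefore enough to turn a compound with no single measured number into one with a real reading, and compound 3 gives 5 ug/mL. Compound 2 gives only a limit, so the printed step is a floor and the real gap may be larger: the limit of > 100 ug/mL in this assay, at which 1 of the 3 values shown sits.

Going by these compounds, a single pair cannot separate what chloro brings from what is lost with dimethylamino, so it remains open whether the gain belongs to chloro itself or would follow from removing dimethylamino. A fluoro, a methoxy or a carboxylic acid at the same place would help to separate the two.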